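The source may hold more compounds than are shown below. What is called first, only, known or untested is meant among the compounds shown, and "the series" means these compounds.

Compounds measured in an assay on isolated protein for inhibition of DNA nucleotidylexotransferase (Homo sapiens), read by scintillation counting, with a stated time of 10 min; on this read-out lower numbers stand for stronger inhibition and higher numbers for weaker inhibition:
- compound 1 `CCOC(=O)C(=O)CC(=O)/C=C/c1cn(CCC(C)C)c2ccccc12`: only a limit, > 40 uM
- compound 2 `CCOC(=O)C(=O)CC(=O)/C=C/c1cn(Cc2ccc(Cl)cc2)c2ccccc12`: 40 uM
- compound 3 `CC(C)CCn1cc(/C=C/C(=O)CC(=O)C(=O)O)c2ccccc21`: 16.3 uM

Compound 3 holds the lowest of the two numbers in this assay; compound 2 is nearest, and the gap is beyond the scatter. Two steps are known. Freeing the acid gave an at least 2.4-fold lower number from compound 1 to compound 3 (0.38 log units; beyond the scatter). Exchanging the group on the chain carbon bound to the aromatic nitrogen gave a number no higher from compound 1 to compound 2 (the limit leaves the size open), so its size is not readable because compound 1 sits at the limit of > 40 uM in this assay, at which 1 of the 3 values shown sits. Compound 4 `O=C(/C=C/c1cn(CC(=O)N2CCOCC2)c2ccccc12)CC(=O)C(=O)O` differs from compound 3 by (morpholin-4-yl)carbonyl in place of isobutyl on a saturated chain carbon bound to an aromatic nitrogen. Only the unreadable step at that place bears on it, so no change beyond the scatter is expected, with a weakening slightly more likely: the expected step is a 1.2-fold higher number from compound 3 to compound 4 (0.09 log units; within the scatter). Compound 4 is estimated at 20 uM, between 6 uM and 60 uM.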

Compound 4, concentration for 50% inhibition: 24 uM
Compound 4: the middle estimate sits 1.2-fold (0.08 log units) below what was measured; low and high end bracket the measured number.
By their numbers in this assay, from the lowest: compounds 3, 4 and 2 (each within the scatter of the next, the first and the last beyond it).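

In this assay, going by these compounds alone, the exchange gave a 1.5-fold higher number from compound 3 to compound 4 (0.17 log units; within the scatter), the first readable step at this place on a saturated chain carbon bound to an aromatic nitrogen. With the free acid, this place carries (morpholin-4-yl)carbonyl, with its six-membered non-aromatic ring, as well as isobutyl, with no change beyond the scatter. The earlier step here cannot be read because compound 1 gives only a limit: the limit of > 40 uM in this assay, at which 1 of the 4 values shown sits.

The compounds shown leave open how 4-chlorophenyl would read on the free acid. They also leave open how an amine or a longer chain would read at this place.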